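From hexyl to benzyl on the shared core

This account rests on a few compounds, and the source may have more. Where it says the series, first, only, none or still open, it means among the compounds named here.

- compound 1 `CCCCCC1(O)C(=O)Nc2ccc(Nc3ccc(OC)cc3)cc21`: 16200 nM
- compound 2 `CCCCCCC1(O)C(=O)Nc2ccc(Nc3ccc(OC)cc3)cc21`: > 100000 nM, a limit
- compound 3 `COc1ccc(Nc2ccc3c(c2)C(O)(Cc2ccccc2)C(=O)N3)cc1`: not yet measured

In a functional assay on NCI-H460 cells (Homo sapiens) for antiproliferative activity, read by MTT assay, with a stated time of 48 h (on this read-out lower numbers stand for stronger inhibition and higher numbers for weaker inhibition), compound 2 gives > 100000 nM, which is a limit and not a number. It stands at the limit of > 100000 nM in this assay, at which 1 of the 2 values shown sits. Compound 3 carries this change: phenyl in place of pentyl on a saturated chain carbon bound to a saturated ring carbon. Hexyl gives way to benzyl. Among the compounds with values here, only one measured step bears on it, the chain extension an at least 6.1-fold higher number from compound 1 to compound 2 (0.79 log units; beyond the scatter), which is beyond the scatter. Removing the hexyl chain of compound 2 is therefore expected to bring the number down, towards compound 1 at 16200 nM. The expected change is an at least 2.8-fold lower number from compound 2 to compound 3 (0.45 log units; beyond the scatter). For compound 3 the estimate is 35000 nM, with an expected range of 9000 nM to 90000 nM.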

Compound 3, half-maximal inhibitory concentration: > 100000 nM
Compound 3: no number, only a limit (the forecaster's own chance of this, stated with the estimate: 25%); middle value at least 2.8-fold (0.45 log units) from the limit.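

In this assay compound 3 gives > 100000 nM, a limit and not a number. Hexyl and benzyl on this saturated ring carbon thus end at the same limit: the limit of > 100000 nM in this assay, at which 2 of the 3 values shown sit. The one readable step is an at least 6.1-fold higher number from compound 1 to compound 3 (0.79 log units; beyond the scatter), so an aromatic ring on this saturated chain carbon does not restore the number of compound 1, while the step from compound 2 to compound 3 cannot be read.

As far as these compounds go, it remains open whether a shorter chain such as propyl would give a lower number than compound 1. Also open, from the compounds shown here alone, is whether a benzyl group carrying an amine would bring the number back within the measurable range.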